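The source may hold more compounds than are shown below. What is called first, only, known or untested is meant among the compounds shown, and "the series" means these compounds.

Measured compounds, with their results in a functional assay for antagonist activity at transient receptor potential cation channel subfamily V member 1 (Homo sapiens), read by FLIPR and calcium flux; a higher number here means a weaker inhibitor, a lower number a stronger inhibitor:
compound 1 `O=C1CSc2ccc(NC(=O)C3CCN(c4cc(F)c(F)c(F)c4)CC3)cc2N1` gives 1960 nM
compound 2 `O=C(Nc1cccc2[nH]ccc12)C1CCN(c2cccc(C(F)(F)F)c2)CC1` gives 230 nM
compound 3 `O=C1COc2ccc(NC(=O)C3CCN(c4cccc(Br)c4)CC3)cc2N1` gives 330 nM

Compound 3 sits with compound 2 among the three measured numbers: the two values fall within the scatter of each other, so nothing separates them. Compound 1 stands apart from compound 3, with a higher number beyond the scatter, and so is the weaker inhibitor of that pair.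

The next compound, compound 4 `COc1cccc(N2CCC(C(=O)Nc3ccc4c(c3)NC(=O)CO4)CC2)c1`, keeps the shared core of compound 3 and differs in one place: methoxy in place of bromo on an aromatic carbon. Among the compounds with values here, no pair of measured compounds shows this same change, so its size has no direct precedent here. Among the three measured compounds, the two with a single meta substituent on that ring, compound 2 and compound 3, give the lower numbers, while compound 1 with a different substitution pattern gives the higher one; that is the whole of what the data show. For compound 4 a modest move toward a higher number is expected, on the order of a 2.7-fold higher number from compound 3 to compound 4 (0.44 log units; beyond the scatter), though the scatter could hide it. The estimate for compound 4 in this assay is 900 nM, expected to lie between 300 nM and 3000 nM.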

Compound 4, half-maximal inhibitory concentration: 1420 nM
Compound 4: middle estimate off by 1.6-fold (0.20 log units), on the low side; measured number inside the range.
By their numbers in this assay, from the lowest: compounds 2 and 3 (each within the scatter of the next); then compounds 4 and 1 (each within the scatter of the next).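

In this assay, within the data shown here, replacing bromo with methoxy on the aromatic carbon meta to a large group gives a 4.3-fold higher number from compound 3 to compound 4 (0.63 log units; beyond the scatter) on an otherwise unchanged core, the first direct reading of this position. The position therefore responds to the identity of its substituent, and of these two groups, the 3-bromophenyl of compound 3 gives the stronger inhibitor, with the step printed as beyond the scatter. The change also adds a heavy atom and brings in a hydrogen-bond acceptor, but no measurement available here separates these differences or accounts for the loss.

Among these compounds, with only two groups compared at this position, a single pair cannot show whether the result tracks the oxygen of methoxy or the particular character of bromo, and chloro, methyl, nitrile or ethoxy on the same core would help to separate those readings. Among the compounds shown here, also open is whether the same step holds when the amide carries a different partner, since only this one pair shows the change.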